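The compounds below may be only part of what the source reports. "The series", "measured", "known", "first", "only" and "open" are said of these compounds alone.

Measured so far:
- compound 1 `CC[C@@H]1C(=O)N(C)c2cnc(Nc3ccc(S(=O)(=O)NC4CCCC4)cc3)nc2N1C1CCCC1`: 389 nM
- compound 3 `CC[C@@H]1C(=O)N(C)c2cnc(-n3ccc4cc(C(=O)NC5CCCC5)ccc43)nc2N1C1CCCC1`: 259 nM
- compound 2 `CCC1C(=O)N(C)c2cnc(Nc3ccc(S(=O)(=O)NCCO)cc3)nc2N1c1ccn(C)n1`: "not active" (no number reported)

In a functional assay on Huh-7 cells (Homo sapiens) for antiproliferative activity, read by CCK-8 assay, with a stated time of 72 h (a higher number here means a weaker inhibitor of growth, a lower number a stronger inhibitor of growth), compound 1 gives 389 nM, the higher of the two numbers in hand. Compound 3 gives 259 nM, a gap within the scatter, so the two cannot be ordered. Compound 2 is recorded as not active, without a number.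

Compound 4 `CC[C@@H]1C(=O)N(C)c2cnc(Nc3ccc(S(=O)(=O)NC)cc3)nc2N1C1CCCC1` differs from compound 1 in one place: methyl in place of cyclopentyl on a sulfonamide nitrogen. Among the compounds with values here, no measured pair shows this change, so the size of the step in this assay is open. Only a small step is expected, within or just beyond the scatter, and if anything toward a higher number; the step from a 1.5-fold higher number from compound 1 to compound 4 (0.19 log units; within the scatter) is an estimate. For compound 4 a value of 600 nM is estimated, between 200 nM and 2000 nM.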

Compound 4, concentration for 50% growth inhibition: 99 nM
The estimate for compound 4 lay 6.1-fold (0.78 log units) above the measured number; measured number below the stated range.
By their numbers in this assay, from the lowest: compound 4; then compounds 3 and 1 (each within the scatter of the next).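

In this assay, within the data shown here, methyl in place of cyclopentyl on a sulfonamide nitrogen gives a 3.9-fold lower number from compound 1 to compound 4 (0.59 log units; beyond the scatter) as the first single-place step. The cyclopentyl ring is therefore not required at this position for growth inhibition, and the smaller group gives the lower number in this pair. No evidence in hand accounts for the step.

From the compounds shown here alone, whether the number keeps moving with ethyl or isopropyl on this nitrogen remains open, as one pair gives no trend. Going by these compounds, the unsubstituted sulfonamide and a longer chain ending in an amine or a carboxylic acid are also open.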